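The source may report more compounds than this note shows. Statements on the series, on what has been measured and on what is new or still open speak of the compounds shown alone.

- Compound 1 `CCCC(=O)NC(c1ccc(Cl)cc1)c1cc(Cl)c2cccnc2c1O`: 100 nM
- Compound 2 `CCCC(=O)NC(c1ccccc1)c1cc(Cl)c2cccnc2c1O`: 110 nM
- Compound 3 `CCCC(=O)NC(c1ccc(N(CC)CC)cc1)c1cc(Cl)c2cccnc2c1O`: not yet measured

In a functional assay on Daoy cells (Homo sapiens) for antiproliferative activity, read by trypan blue exclusion and crystal violet staining, with a stated time of 72 h (on this read-out lower numbers stand for stronger inhibition and higher numbers for weaker inhibition), compound 2 gives 110 nM. Among the measured compounds shown here, that places it level with compound 1, the only other measured compound, since the two values lie within the scatter of each other.

Compound 3 keeps the core and butanamide-free details of neither more nor less than compound 2 except for one change: diethylamino in place of hydrogen on an aromatic carbon.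

For the measured compounds named here, only one measured step bears on this change. It concerns an aromatic carbon too, and it is a 1.1-fold higher number from compound 1 to compound 2 (0.04 log units; within the scatter). Swapping chloro for hydrogen there therefore left no mark beyond the scatter. Going by the values given here, that is a useful but thin guide, since no measured compound carries anything resembling diethylamino, and a single step cannot show how much room this spot allows.

The expected step is a 1.4-fold higher number from compound 2 to compound 3 (0.13 log units; within the scatter), a slight lean toward weaker inhibition that may well stay within the scatter. For compound 3 the estimated value is 150 nM, with an expected range from 50 nM to 450 nM.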

Compound 3, half-maximal inhibitory concentration: 100 nM
Compound 3: the middle estimate sits 1.5-fold (0.18 log units) above what was measured; low and high end bracket the measured number.
By their numbers in this assay, from the lowest: compounds 1, 3 and 2 (each within the scatter of the next).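

In this assay, putting diethylamino, with its 5 heavy atoms, on this aromatic carbon in place of hydrogen gives a 1.1-fold lower number from compound 2 to compound 3 (0.04 log units; within the scatter) and so leaves no mark beyond the scatter. Set against chloro at the same place, the same group gives no change at the digits printed from compound 1 to compound 3 (within the scatter) and again stays within the scatter. The earlier pair compared only hydrogen with chloro, whereas these compounds show that a branched group with nitrogen and 4 carbon atoms, para to a large group on this six-membered aromatic ring of carbon only, can sit here without moving the number beyond the scatter, so hydrogen, chloro and diethylamino all read alike in this series.

Nothing available explains why these three compounds read alike, and no measurement here goes beyond this one cell read-out.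
Still open is whether this position would stay just as indifferent to a carboxylic acid, a primary amine or a longer carbon chain, since all three compounds shown carry only hydrogen, chloro or diethylamino at this place.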